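From methoxy to bromo: one unmeasured step

A few compounds are considered here, and "the series" means these few. Any claim that something is new, unique, unknown or untested is made for them only; others in the source may bear on it.

Compound 1 `COc1cccc(C(=O)O[C@@H]2C[C@H](C)CC[C@H]2C(C)C)c1` gives 4.57
Compound 2 `CC(C)[C@@H]1CC[C@@H](C)C[C@H]1OC(=O)c1ccccc1Cl` gives 5.34

In a physicochemical assay for lipophilicity, measured as octanol-water partition (on this read-out higher numbers stand for higher lipophilicity and lower numbers for lower lipophilicity), compound 1 stands lowest of the two at 4.57 and compound 2 lies above it by more than the usual scatter. Compound 3 `CC(C)[C@@H]1CC[C@@H](C)C[C@H]1OC(=O)c1cccc(Br)c1` has not been measured yet. It differs from compound 1 by having bromo in place of methoxy on an aromatic carbon. Going by the values given here, no measured pair shows this change alone, so its size is a judgement: a rise beyond the scatter is expected, with compound 2 at 5.34 as a rough guide. The expected change is a number 0.88 log units higher from compound 1 to compound 3 (beyond the scatter) on this estimate. Compound 3 is estimated at 5.45 (expected range 5.05 to 5.85).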

Compound 3, partition coefficient: 5.61
Beside the measured number, compound 3's estimate is 0.16 log units below it; the range from low to high includes it.
By their numbers in this assay, from the lowest: compound 1; then compounds 2 and 3 (each within the scatter of the next).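

With the rest of the molecule unchanged, putting bromo in place of methoxy on an aromatic carbon, meta to a large group, gives a number 1.04 log units higher from compound 1 to compound 3 (beyond the scatter) in this assay. Going by these compounds alone, this is the only pair here that differs in one place, so it isolates this change at this position, and the step counts as large. Nothing measured here explains the size of the step. Still open, on these data alone, is how an amine, a carboxylic acid or a longer chain at this position would compare with bromo and methoxy.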